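Cytotoxicity limits and the (but-3-en-1-yl)oxy change

A few compounds are considered here, and "the series" means these few. Any claim that something is new, unique, unknown or untested is made for them only; others in the source may bear on it.

Of the compounds shown here, three have been read in an ADME assay on RAW264.7 cells (Mus musculus) for cytotoxicity, read by MTT assay, with a stated time of 24 h, in the absence of a further agent (a higher number here means a weaker inhibitor, a lower number a stronger inhibitor), so far. Compound 1 (`O=C1OC(Cc2nc(-c3ccc(Oc4ccccc4)cc3)no2)c2ccccc21`) gives > 40000 nM as a limit. Compound 2 (`CCCOc1ccc(C(O)C2OC(=O)c3c(OC)cc(OC)cc32)cc1`) gives > 40000 nM as a limit. Compound 3 (`COCCOc1ccc(C(O)C2OC(=O)c3c(OC)cc(OC)cc32)cc1`) gives > 40000 nM as a limit, so it has no numerical position in the series. The whole data set amounts to the limit of > 40000 nM in this assay, at which 3 of the 3 values shown sit, and nothing finer.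

Compound 4 (`C=CCCOc1ccc(C(O)C2OC(=O)c3c(OC)cc(OC)cc32)cc1`) differs from compound 3 by vinyl in place of methoxy on a saturated chain carbon, two bonds along the chain from an oxygen on an aromatic ring and the 2-methoxyethoxy thus becomes (but-3-en-1-yl)oxy. Among the measured compounds shown here, one measured step bears on this place in the chain. No step beyond the scatter is expected in this assay and no direction can be assigned, because a step that the two limits leave unreadable from compound 2 to compound 3 gives no size to build on. The expected outcome is a further reading at the limit. The estimated step is a step that the limit leaves unreadable from compound 3 to compound 4 and it carries little weight. For compound 4 the estimated value is 50000 nM with an expected range from 25000 nM to 100000 nM as a working figure.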

Compound 4, half-maximal inhibitory concentration: > 40000 nM
Compound 4 was reported as a limit; the forecaster's own chance of this, stated with the estimate: 85%; the middle value does not contradict the limit.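

Compound 2, compound 3 and compound 4 all stand as limits in this assay, so no step among them can be read: the limit of > 40000 nM in this assay, at which 4 of the 4 values shown sit.

The compounds shown leave open whether any change on this chain would give a numerical reading in this assay rather than a limit.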